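The source may report more compounds than this note shows. Statements on the series, on what has been measured and on what is new or still open speak of the compounds shown alone.

Compound 1, `COc1cc(-c2cc(/C=C/C(=O)c3ccc(Cl)c(Cl)c3)[nH]n2)cc(OC)c1OC`, gives 23%. Compound 2, `COc1ccc(C(=O)/C=C/c2cc(-c3cc(OC)c(OC)c(OC)c3)n[nH]2)cc1OC`, gives 11%.

Compound 2 stands lowest of the two numbers in a functional assay on SR cells (Homo sapiens) for cytotoxicity, read by sulforhodamine B assay, with a stated time of 48 h, tested at 1 uM (on this read-out higher numbers stand for a weaker effect at the one concentration tested and lower numbers for a stronger effect), the nearest being compound 1 at a number that is a number 12 percentage points lower from compound 1 to compound 2 (beyond the scatter). Compound 3, `COc1ccc(C(=O)/C=C/c2cc(-c3cc(OC)c(OC)c(OC)c3)n[nH]2)cc1`, differs from compound 2 by hydrogen in place of methoxy on an aromatic carbon. Going by the values given here, the only measured step, from compound 1 to compound 2, changes a group on the carbonyl carbon and does not touch a methoxy on the ring; it is therefore of limited bearing, and no step for this exact change exists. The expected step is a number 7 percentage points higher from compound 2 to compound 3 (within the scatter), within the scatter. For compound 3 the estimate is 18%, ranging from 4% to 40%.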

Compound 3, a percentage reported as activity, at one concentration (the size of the read-out at that concentration, not a potency): 22%
Estimate against measurement, compound 3: 4 percentage points below; measured number inside the range.
By their numbers in this assay, from the lowest: compound 2; then compounds 3 and 1 (each within the scatter of the next).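

In this assay, the loss of this methoxy group, which turns 3,4-dimethoxyphenyl into 4-methoxyphenyl, comes with a number 11 percentage points higher from compound 2 to compound 3 (beyond the scatter), so the stronger effect of compound 2 needs both methoxy groups on that ring. The comparison with the dichloro analogue, a number 1 percentage points lower from compound 1 to compound 3 (within the scatter), shows that 4-methoxyphenyl and 3,4-dichlorophenyl cannot be told apart here. Nothing available explains this difference. The compounds shown leave open whether a hydroxyl, an amine or a longer ethoxy chain at this place would match the methoxy group of compound 2.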